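Indazolyl series: aryl change on the sulfonyl nitrogen substituent

A few compounds are considered here, and "the series" means these few. Any claim that something is new, unique, unknown or untested is made for them only; others in the source may bear on it.

Compound 1, `CN(C(=O)c1ccc(F)cc1)c1ccc2[nH]c(-c3n[nH]c4ccccc34)cc2n1`, gives 7220 nM in a functional assay on KB cells (Homo sapiens) for antiproliferative activity, read by MTT assay, with a stated time of 72 h; on this read-out higher numbers stand for weaker inhibition and lower numbers for stronger inhibition.
Compound 2, `CN(C(=O)c1ccco1)c1ccc2[nH]c(-c3n[nH]c4ccccc34)cc2n1`, gives 19400 nM in this assay.
Compound 3, `CN(c1ccc2[nH]c(-c3n[nH]c4ccccc34)cc2n1)S(=O)(=O)c1ccc(Cl)cc1`, gives 8350 nM in this assay.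

Compound 3 stands second highest of the three numbers: a 1.2-fold higher number from compound 1 to compound 3 (0.06 log units; within the scatter), while a 2.3-fold lower number from compound 2 to compound 3 (0.37 log units; beyond the scatter). Compound 4, `COc1ccc(S(=O)(=O)N(C)c2ccc3[nH]c(-c4n[nH]c5ccccc45)cc3n2)c(OC)c1`, differs from compound 3 in one place: 2,4-dimethoxyphenyl in place of 4-chlorophenyl on a sulfonyl sulfur. Going by the values given here, no measured step varies the aryl group on the sulfonyl sulfur, so nothing bears on it directly. Among the compounds with values here, the only aryl exchange in the set sits on a carbonyl carbon, where a 2.7-fold higher number from compound 1 to compound 2 (0.43 log units; beyond the scatter), a modest shift; the two exchanges at the ring nitrogen, a 1.2-fold higher number from compound 1 to compound 3 (0.06 log units; within the scatter) and a 2.3-fold lower number from compound 2 to compound 3 (0.37 log units; beyond the scatter), were within scatter or modest. All three measured values lie within a narrow band. On this basis a step of no more than modest size in this assay is expected for compound 4, with no clear direction, so the estimate is set near compound 3 with a wide range. Compound 4 is expected to give 9000 nM, between 3500 nM and 25000 nM, which means an expected step of a 1.1-fold higher number from compound 3 to compound 4 (0.03 log units; within the scatter).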

Compound 4, half-maximal inhibitory concentration: 10200 nM
Estimate against measurement, compound 4: 1.1-fold (0.05 log units) below; the range from low to high includes it.
By their numbers in this assay, from the lowest: compounds 1, 3, 4 and 2 (each within the scatter of the next, the first and the last beyond it).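

In this assay, going by these compounds alone, the only measured exchange of the aryl group on a sulfonyl sulfur gives a 1.2-fold higher number from compound 3 to compound 4 (0.09 log units; within the scatter), so 2,4-dimethoxyphenyl and 4-chlorophenyl cannot be told apart at this position. The entering group carries more heavy atoms and more hydrogen-bond acceptors than the leaving one, and the chlorine is lost, yet these differences together bring no step beyond the scatter. No supporting data bear on this result.

With both substituents changed at once, the compounds shown cannot separate the contribution of each methoxy group, and a plain phenyl or a 4-methoxyphenyl on the sulfonyl sulfur would be needed for that. Also open, on these data alone, is whether an amine or a carboxylic acid on the aryl ring, or a butyl chain in place of that ring, would move the number beyond the scatter.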